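A few compounds are considered here, and "the series" means these few. Any claim that something is new, unique, unknown or untested is made for them only; others in the source may bear on it.

Measured so far:
- Compound 1 `CO[C@H]1CC[C@H](CN2C(=O)CNc3ncc(-c4ccc(-c5nc[nH]n5)nc4C)nc32)CC1`: 90%
- Compound 2 `Cc1nc(-c2nc[nH]n2)ccc1-c1cnc2c(n1)N(CC1CCOCC1)C(=O)CN2`: 100%

Going by the values given here, in an ADME assay on S9 fraction from liver (Homo sapiens) for metabolic stability, with a stated time of 60 min (on this read-out higher numbers stand for a more stable compound and lower numbers for a less stable compound), compound 2 gives 100%, which lies within the scatter of the only other measured compound, compound 1. Compound 3 `CO[C@H]1CC[C@@H](CN2C(=O)CNc3ncc(-c4ccc(-c5nc[nH]n5)nc4C)nc32)CC1` differs from compound 2 by one change: 4-methoxycyclohexyl in place of oxan-4-yl on a saturated chain carbon bound to an amide-type nitrogen in a ring. In words, it has 4-methoxycyclohexyl in place of oxan-4-yl on a saturated chain carbon bound to an amide-type nitrogen in a ring. Among the compounds with values here, the one measured step that bears on this is the same exchange run the other way, a number 10 percentage points higher from compound 1 to compound 2 (within the scatter). No change beyond the scatter is therefore expected, and the expected step is a number 10 percentage points lower from compound 2 to compound 3 (within the scatter). The estimate for compound 3 is 90%, with an expected range of 75% to 100%.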

Compound 3, percent of the compound remaining: 10%
Compound 3: middle estimate off by 80 percentage points, on the high side, and the stated range ends above it.
By their numbers in this assay, from the lowest: compound 3; then compounds 1 and 2 (each within the scatter of the next).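

In this assay, the name 4-methoxycyclohexyl alone does not settle the outcome at this saturated chain carbon: in place of oxan-4-yl it now gives a number 90 percentage points lower from compound 2 to compound 3 (beyond the scatter) while compound 1, with the same group as drawn differently, stays within the scatter of compound 2. The drop seen in a number 80 percentage points lower from compound 1 to compound 3 (beyond the scatter) can be traced to a single feature: the fact that compounds 1 and 3 differ only in the configuration as drawn. What the compounds shown leave open is whether 4-hydroxycyclohexyl or 4-aminocyclohexyl in place of 4-methoxycyclohexyl would show a similar gap between its two drawn configurations.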